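Swapping the Amide Aryl Group in an Antiproliferative Series

A few compounds are considered here, and "the series" means these few. Any claim that something is new, unique, unknown or untested is made for them only; others in the source may bear on it.

Within the data shown here, compound 1, `O=C(Nc1cccc(-c2oc3cc(-c4ccc(F)cc4)ccc3c(=O)c2O)c1)c1ccc(F)cc1`, was tested in a functional assay on MCF7 cells (Homo sapiens) for antiproliferative activity, read by CCK-8 assay, with a stated time of 72 h (on this read-out lower numbers stand for stronger inhibition and higher numbers for weaker inhibition), where compound 1 gives 8590 nM, the lowest of the two numbers known. Compound 2, `O=C(Nc1cccc(-c2oc3cc(-c4ccc(F)cc4)ccc3c(=O)c2O)c1)c1ccc(F)cc1F`, gives 13500 nM in this assay, and the step of a 1.6-fold higher number from compound 1 to compound 2 (0.20 log units; within the scatter) comes from fluoro in place of hydrogen on an aromatic carbon. Compound 3, `COc1ccccc1C(=O)Nc1cccc(-c2oc3cc(-c4ccc(F)cc4)ccc3c(=O)c2O)c1`, differs from compound 1 by 2-methoxyphenyl in place of 4-fluorophenyl on a carbonyl carbon. Among the measured compounds shown here, no measured step addresses this change, and the one step known stayed within the scatter, so the expected step is a 1.0-fold higher number from compound 1 to compound 3 (0.02 log units; within the scatter), not beyond the scatter. Compound 3 is estimated at 9000 nM, between 3000 nM and 27000 nM.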

Compound 3, half-maximal inhibitory concentration: 2100 nM
For compound 3 the middle estimate is 4.3-fold (0.63 log units) above the measured one; the whole stated range lies above it.
By their numbers in this assay, from the lowest: compound 3; then compounds 1 and 2 (each within the scatter of the next).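

In this assay the aryl group on the carbonyl carbon proves able to move the number beyond the scatter: 2-methoxyphenyl in place of 4-fluorophenyl gives a 4.1-fold lower number from compound 1 to compound 3 (0.61 log units; beyond the scatter) and in place of 2,4-difluorophenyl gives a 6.4-fold lower number from compound 2 to compound 3 (0.81 log units; beyond the scatter) as well. The earlier fluoro change on this ring stayed within the scatter, so only a swap of this larger kind has shifted the result so far. No measurement on hand explains the step.

On these data alone, whether the methoxy group itself or its place on the ring carries the step stays open. So does how an amine, a carboxylic acid or a longer chain on this carbonyl carbon would read.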